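The source may report more compounds than this note shows. Statements on the series, on what has been measured and on what is new or still open speak of the compounds shown alone.

Measured so far:
Compound 2 `CC(c1ccc(-c2ccccc2)c(F)c1)c1nnc2n1N=C(c1ccc(Cl)cc1Cl)CS2`: 5400 nM
Compound 1 `Cc1ccc(C2=Nn3c(nnc3C(C)c3ccc(CC(C)C)cc3)SC2)cc1`: 6800 nM
Compound 3 `COc1ccc2cc(C(C)c3n[nH]c(=S)n3N)ccc2c1`: "not active" (no number reported)

In a functional assay on FOCUS cells (Homo sapiens) for inhibition, read by sulforhodamine B assay, with a stated time of 72 h (on this read-out higher numbers stand for weaker inhibition and lower numbers for stronger inhibition), compound 2 gives 5400 nM. Compound 1 gives 6800 nM in this assay, and the two numbers lie within the usual scatter of each other, so they cannot be told apart. Compound 3 was reported as not active, with no number attached.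

Compound 4 `CC(c1ccc(-c2ccccc2)c(F)c1)c1nnc2n1N=C(c1ccc(Br)cc1)CS2` differs from compound 2 in one place: 4-bromophenyl in place of 2,4-dichlorophenyl on a carbon with a double bond to nitrogen. Among the measured compounds shown here, no step between measured compounds covers a change of this kind, so the expectation rests on compound 2 alone. The expected step is a 1.2-fold higher number from compound 2 to compound 4 (0.08 log units; within the scatter), nothing beyond the scatter in either direction. Compound 4 is therefore estimated at 6500 nM, with a range from 2500 nM to 17000 nM.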

Compound 4, half-maximal inhibitory concentration: 8500 nM
For compound 4 the middle estimate is 1.3-fold (0.12 log units) below the measured one; the range from low to high includes it.
By their numbers in this assay, from the lowest: compounds 2, 1 and 4 (each within the scatter of the next).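

In this assay, 4-bromophenyl in place of 2,4-dichlorophenyl gives a 1.6-fold higher number from compound 2 to compound 4 (0.20 log units; within the scatter), so the two compounds cannot be told apart. Among the compounds shown here, this is the first one-place step at this carbon with a double bond to nitrogen, and it shows that these two aryl groups give numbers within the scatter of each other. Nothing measured here explains this result. On these data alone, whether an amine, a carboxylic acid or a saturated cyclohexyl ring at this position would move the number beyond the scatter remains open.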